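The compounds below may be only part of what the source reports. "The series", "measured", "known", "first", "only" and "open" are said of these compounds alone.

Compound 1 `CC1(C)C(=O)N(c2ccc(SC(F)(F)F)cc2)C(=O)N1Cc1ccnc(N2CCCCC2)c1`, compound 2 `CN1CCN(c2cc(CN3C(=O)N(c4ccc(SC(F)(F)F)cc4)C(=O)C3(C)C)ccn2)CC1` and compound 3 `CC1(C)C(=O)N(c2ccc(SC(F)(F)F)cc2)C(=O)N1Cc1ccnc(N2CCNCC2)c1` share one core and differ only in a single ring amine group. In a physicochemical assay for solubility, read by nephelometry (on this read-out lower numbers stand for lower solubility and higher numbers for higher solubility), compound 3 gives < 0.024 ug/mL, which is a limit of the assay and not a number. Compound 1 gives < 0.024 ug/mL, which is also a limit. Compound 2 alone gives a number, 0.159 ug/mL. Compound 3 therefore stands at the limit of < 0.024 ug/mL in this assay, at which 2 of the 3 values shown sit.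

The next structure, compound 4 `CC1(C)C(=O)N(c2ccc(SC(F)(F)F)cc2)C(=O)N1Cc1ccnc(C(=O)O)c1`, has carboxy in place of piperazin-1-yl on an aromatic carbon, next to the ring nitrogen: carboxy in place of piperazin-1-yl on an aromatic carbon.

The measured steps bear on this place only indirectly, since all of them exchange one amine group for another. They comprise an at least 6.6-fold higher number from compound 1 to compound 2 (0.82 log units; beyond the scatter), then an at least 6.6-fold lower number from compound 2 to compound 3 (0.82 log units; beyond the scatter), and finally a step that the two limits leave unreadable from compound 1 to compound 3. The two readable steps show that a change at this position can move the read-out beyond the scatter, yet none of them involves carboxy, so the size of the next step remains uncertain.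

With compound 3 resting at the limit of < 0.024 ug/mL in this assay, at which 2 of the 3 values shown sit, any readable result for compound 4 would have to lie upward. The expected change is an at least 20-fold higher number from compound 3 to compound 4 (1.31 log units; beyond the scatter), a rise of at least modest size. For compound 4 the estimated value is 0.5 ug/mL, with an expected range from 0.03 ug/mL to 10 ug/mL.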

Compound 4, solubility: 0.142 ug/mL
Compound 4: middle estimate off by 3.5-fold (0.55 log units), on the high side, and the stated range covers the measured number.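

In this assay, carboxy on this aromatic carbon gives a readable number where piperazin-1-yl and piperidin-1-yl do not, and the read-out shows an at least 5.9-fold higher number from compound 3 to compound 4 (0.77 log units; beyond the scatter) and an at least 5.9-fold higher number from compound 1 to compound 4 (0.77 log units; beyond the scatter). Both of these steps start from a limit of the assay and not from a number, so their true size stays open: the limit of < 0.024 ug/mL in this assay, at which 2 of the 4 values shown sit.

Among the earlier compounds, only compound 2, with 4-methylpiperazin-1-yl, gave a readable number, but the result for carboxy, a group with no ring, now shows that a ring amine is not needed for one at this position, and the two groups cannot be told apart, with a 1.1-fold lower number from compound 2 to compound 4 (0.05 log units; within the scatter).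

The compounds shown leave open whether this readable number is particular to carboxy, a question that a primary amide, a methyl ester or a longer chain ending in a carboxylic acid on the same carbon could help to answer. They also leave open why 4-methylpiperazin-1-yl gives a number while piperazin-1-yl, differing from it only by a methyl on the ring nitrogen, does not, and a simple primary amine at this place would add a further comparison.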